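Trifluoromethyl to Chloro on the Aryl Ring

The source may hold more compounds than are shown below. What is called first, only, known or untested is meant among the compounds shown, and "the series" means these compounds.

Compound 1, `COc1cc(-n2cnc3ccc(-c4ccc([N+](=O)[O-])cc4)cc32)cc(OC)c1OC`: in a functional assay on MCF7 cells (Homo sapiens) for antiproliferative activity, read by MTT assay, with a stated time of 72 h (a lower number here means a stronger inhibitor, a higher number a weaker inhibitor), compound 1 gives 740 nM.
Compound 2, `COc1cc(-n2cnc3ccc(-c4cccc(F)c4)cc32)cc(OC)c1OC`: in this assay compound 2 gives 2350 nM.
Compound 3, `COc1cc(-n2cnc3ccc(-c4ccc(C(F)(F)F)cc4)cc32)cc(OC)c1OC`: in this assay compound 3 gives 760 nM.

Compound 3 stands second highest of the three numbers. Its nearest neighbour is compound 1, with a 1.0-fold higher number from compound 1 to compound 3 (0.01 log units; within the scatter), a step within the scatter; the furthest is compound 2, where a 3.1-fold lower number from compound 2 to compound 3 (0.49 log units; beyond the scatter) lies beyond the scatter. Compound 4, `COc1cc(-n2cnc3ccc(-c4ccc(Cl)cc4)cc32)cc(OC)c1OC`, differs from compound 3 by chloro in place of trifluoromethyl on an aromatic carbon. The step that bears most directly on this change is a 1.0-fold higher number from compound 1 to compound 3 (0.01 log units; within the scatter), an exchange of one group on the same aromatic carbon that moved nothing beyond the scatter. The steps of a 3.2-fold higher number from compound 1 to compound 2 (0.50 log units; beyond the scatter) and a 3.1-fold lower number from compound 2 to compound 3 (0.49 log units; beyond the scatter) both involve 3-fluorophenyl and bear less directly. The author therefore expects no step beyond the scatter in this assay for compound 4. For compound 4 the estimated value is 850 nM, with a range from 350 nM to 2000 nM. The expected step is a 1.1-fold higher number from compound 3 to compound 4 (0.05 log units; within the scatter).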

Compound 4, half-maximal inhibitory concentration: 1320 nM
Beside the measured number, compound 4's estimate is 1.6-fold (0.19 log units) below it, and the stated range covers the measured number.
By their numbers in this assay, from the lowest: compounds 1, 3, 4 and 2 (each within the scatter of the next, the first and the last beyond it).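

In this assay, chloro on this aromatic carbon stays within the scatter of both groups seen there before, with a 1.7-fold higher number from compound 3 to compound 4 (0.24 log units; within the scatter) against trifluoromethyl and a 1.8-fold higher number from compound 1 to compound 4 (0.25 log units; within the scatter) against nitro, so these three groups cannot be told apart here. The 4-chlorophenyl compound is also within the scatter of the 3-fluorophenyl compound, at a 1.8-fold lower number from compound 2 to compound 4 (0.25 log units; within the scatter), although a 3.2-fold higher number from compound 1 to compound 2 (0.50 log units; beyond the scatter) and a 3.1-fold lower number from compound 2 to compound 3 (0.49 log units; beyond the scatter) both lie beyond it, so the gap that separated compound 2 from the other two is now bridged by an intermediate number. No measurement at hand accounts for any of these steps.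

The compounds shown leave open whether an amine or a carboxylic acid on this aromatic carbon would stay within the same scatter. They also leave open how a hydroxyl or a longer alkyl chain would read there.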